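Title: From cyclohexylamino to 2,6-dimethylmorpholin-4-yl on the shared core

This account rests on a few compounds, and the source may have more. Where it says the series, first, only, none or still open, it means among the compounds named here.

Measured compounds:
Compound 1, `c1ccc(-c2ccc3oc(NC4CCCCC4)nc3c2)cc1`, > 1000 nM
Compound 2, `Cn1ccc2cc(-c3ccc4oc(NC5CCCCC5)nc4c3)ccc21`, 911 nM
Compound 3, `c1cc2c(ccn2C2COC2)cc1-c1ccc2oc(NC3CCCCC3)nc2c1`, 579 nM

Three compounds have been run in an assay on HEK293 cells for inhibition of Fatty-acid amide hydrolase 1 (Homo sapiens), read by fluorescence; a higher number here means a weaker inhibitor, a lower number a stronger inhibitor. Compound 1, `c1ccc(-c2ccc3oc(NC4CCCCC4)nc3c2)cc1`, gives only a limit there, > 1000 nM, and this limit is the one recorded at the limit of > 1000 nM in this assay, at which 1 of the 3 values shown sits. Compound 2, `Cn1ccc2cc(-c3ccc4oc(NC5CCCCC5)nc4c3)ccc21`, gives 911 nM. Compound 3, `c1cc2c(ccn2C2COC2)cc1-c1ccc2oc(NC3CCCCC3)nc2c1`, gives 579 nM, and the step of a 1.6-fold lower number from compound 2 to compound 3 (0.20 log units; within the scatter) is oxetan-3-yl in place of methyl on an aromatic nitrogen, a difference that stays within the scatter. Within the data shown here, compound 2 therefore stands with the one other number at hand, and compound 3 is indistinguishable from it on these data.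

Compound 4, `C[C@@H]1CN(c2nc3cc(-c4ccc5c(ccn5C)c4)ccc3o2)C[C@H](C)O1`, is not yet measured. It differs from compound 2 by 2,6-dimethylmorpholin-4-yl in place of cyclohexylamino on an aromatic carbon. Among the measured compounds shown here, no measured step touches this part of the shared core; the only step known, from compound 2 to compound 3, concerns the aromatic nitrogen elsewhere and was small. The loss of the hydrogen-bond donor counted above cannot be weighed against any shown evidence, so no direction beyond the scatter can be argued from the data. Compound 4 is therefore expected to land near compound 2, with wide uncertainty, at an estimated 1200 nM (range 300 nM to 5000 nM). The expected step is a 1.3-fold higher number from compound 2 to compound 4 (0.12 log units; within the scatter).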

Compound 4, half-maximal inhibitory concentration: 168 nM
Estimate against measurement, compound 4: 7.1-fold (0.85 log units) above, and the stated range ends above it.
By their numbers in this assay, from the lowest: compound 4; then compounds 3 and 2 (each within the scatter of the next). At a limit, above all of these: compound 1.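

In this assay, among these compounds, the aromatic carbon next to the ring nitrogen and next to the ring oxygen proves responsive to change: 2,6-dimethylmorpholin-4-yl in place of cyclohexylamino gives a 5.4-fold lower number from compound 2 to compound 4 (0.73 log units; beyond the scatter), whereas the only earlier step, at the aromatic nitrogen, gave a 1.6-fold lower number from compound 2 to compound 3 (0.20 log units; within the scatter). This single pair also shows that the hydrogen-bond donor of cyclohexylamino is not required for inhibition on this core, since compound 4 has no donor in the entering group and still gives the lowest number of the pair. Nothing shown here accounts for the size or direction of this step, and the change alters the ring atoms, the substituents and the stereocentres all at once.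

The compounds shown leave open whether the ring oxygen, the two methyl groups or their defined stereochemistry carries the step, a question that unsubstituted morpholin-4-yl and piperidin-1-yl at the same carbon would help to separate. They also leave open whether 2,6-dimethylmorpholin-4-yl and oxetan-3-yl on the aromatic nitrogen would act together on the shared core.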